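Isopropyl to 1,1-difluoroethyl: an expectation from one number

A few compounds are considered here, and "the series" means these few. Any claim that something is new, unique, unknown or untested is made for them only; others in the source may bear on it.

Of the compounds shown here, three have been tested in an ADME assay on cells for inhibition of cytochrome P450 11B1, mitochondrial (Homo sapiens), read by HPLC, with a stated time of 60 min; a higher number here means a weaker inhibitor, a lower number a stronger inhibitor. Compound 1 `Fc1ccc2nc(-c3cnco3)n(C3CC3)c2c1` is reported in this assay only as a limit, > 10000 nM. Compound 2 `Fc1ccc2nc(-c3ccnnc3)n(C3CC3)c2c1` likewise gives a limit in this assay, > 10000 nM. The step that the two limits leave unreadable from compound 1 to compound 2 therefore has no readable size. For the measured compounds named here, compound 3 `CC(C)c1ncncc1-c1nc2cc(F)c(F)cc2n1C1CC1` is the only compound with a measured number, giving 1910 nM in this assay, and it stands apart from the other two because the limit of > 10000 nM in this assay, at which 2 of the 3 values shown sit, holds both of them.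

Compound 4 `CC(F)(F)c1ncncc1-c1nc2cc(F)c(F)cc2n1C1CC1` has not yet been measured. It differs from compound 3 by 1,1-difluoroethyl in place of isopropyl on an aromatic carbon. Going by the values given here, no measured step touches this group: the single measured step, a step that the two limits leave unreadable from compound 1 to compound 2, concerns a different part of the structure and cannot be read in size. The expectation for compound 4 therefore rests only on the value of compound 3, 1910 nM, with a change expected to stay within the usual scatter. The step of a 1.0-fold lower number from compound 3 to compound 4 (0.00 log units; within the scatter) is accordingly estimated to be small. Compound 4 is expected to give about 1900 nM in this assay, within a range from 700 nM to 5500 nM.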

Compound 4, half-maximal inhibitory concentration: 5720 nM
Estimate against measurement, compound 4: 3.0-fold (0.48 log units) below; the whole stated range lies below it.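

In this assay, for the compounds shown here, 1,1-difluoroethyl in place of isopropyl gives a 3.0-fold higher number from compound 3 to compound 4 (0.48 log units; beyond the scatter), the first step in this set whose size can be read. Going by these compounds alone, it is also the first measured step at this position, on a six-membered aromatic ring with 2 nitrogen, and it shows that inhibition changes here even though neither group brings a ring, a hydrogen-bond donor or acceptor, or a net charge. The data shown give the size of this loss of inhibition but offer no measured explanation for it.

Going by these compounds, whether methyl, trifluoromethyl or an amine at this position would give a stronger or a weaker inhibitor remains open. On these data alone, this change also rests on a single pair of compounds, so its size on another core is unknown.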